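Chloro to Trifluoromethyl on the Fluorophenyl Ring

This account rests on a few compounds, and the source may have more. Where it says the series, first, only, none or still open, it means among the compounds named here.

Measured compounds:
Compound 1, `CC[C@H](NC(C)=O)c1cc(Cl)ccc1C1CCN(C(=O)[C@@H]2CN(C(C)(C)C)C[C@H]2c2ccc(F)cc2F)CC1`, in an assay on CHO cells for displacement of a labelled ligand from Melanocortin receptor 4 (Homo sapiens) (a lower number here means a stronger inhibitor, a higher number a weaker inhibitor), gives 70 nM.
Compound 2, `CC[C@H](NC(C)=O)c1cc(Cl)ccc1C1CCN(C(=O)[C@@H]2CN(C(C)(C)C)C[C@H]2c2ccc(Cl)cc2F)CC1`, in this assay gives 6.2 nM.

Going by the values given here, compound 2 holds the lowest of the two numbers so far, and its only neighbour is compound 1: the step of an 11-fold lower number from compound 1 to compound 2 (1.05 log units; beyond the scatter) separates them, a change of chloro in place of fluoro on an aromatic carbon. Compound 3, `CC[C@H](NC(C)=O)c1cc(Cl)ccc1C1CCN(C(=O)[C@@H]2CN(C(C)(C)C)C[C@H]2c2ccc(C(F)(F)F)cc2F)CC1`, has not yet been measured in this assay. Its difference from compound 2 is trifluoromethyl in place of chloro on an aromatic carbon.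

Among the compounds with values here, the one measured step bears on this only loosely: it shows that the group at this position on the fluorophenyl ring matters a great deal, with compound 2 far ahead of compound 1, but it gives no direct reading of trifluoromethyl against chloro. Within the data shown here, with no second step to set the direction, compound 3 is expected to stay near compound 2, with a wide range allowing either a small gain or a moderate loss; the expected step is a 1.3-fold higher number from compound 2 to compound 3 (0.11 log units; within the scatter). Compound 3 is therefore estimated at 8 nM in this assay, within 2.5 nM to 25 nM.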

Compound 3, half-maximal inhibitory concentration: 22.7 nM
Compound 3: the middle estimate sits 2.8-fold (0.45 log units) below what was measured; measured number inside the range.
By their numbers in this assay, from the lowest: compound 2; then compound 3; then compound 1.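

In this assay, the change to trifluoromethyl gives a 3.7-fold higher number from compound 2 to compound 3 (0.56 log units; beyond the scatter) and so shows that chloro at this place, para to a large group, is ahead of a second replacement as well as of fluoro. Trifluoromethyl still keeps a lead over fluoro, with a 3.1-fold lower number from compound 1 to compound 3 (0.49 log units; beyond the scatter) as the step, which puts the three groups in a single order, from the lowest number: chloro, trifluoromethyl, fluoro, with every step beyond the usual scatter. This order does not follow the heavy-atom count, since trifluoromethyl, with 4 heavy atoms, falls between two groups of 1 heavy atom each, and nothing available here accounts for the order.

The compounds shown leave open where other groups at this place, such as bromo, methyl, methoxy or nitrile, would fall in this order, and whether any of them would pass chloro. They also leave open whether the same order would hold with the acetamide side chain or the tert-butyl group of the shared core replaced by another group.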